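The source may hold more compounds than are shown below. What is called first, only, known or untested is meant among the compounds shown, and "the series" means these compounds.

Measured compounds:
Compound 1 `CN(C)c1nc(N[C@H]2CC[C@@H](NC(=O)c3cccc(C#N)c3)CC2)nc2ccccc12` — in an assay on HEK293 cells for inhibition of melanin-concentrating hormone receptor 1 (Homo sapiens), read by radioligand binding (on this read-out higher numbers stand for weaker inhibition and lower numbers for stronger inhibition), compound 1 gives 10 nM.
Compound 2 `Cc1cccc(C(=O)N[C@H]2CC[C@@H](Nc3nc(N(C)C)c4ccccc4n3)CC2)c1` — in this assay compound 2 gives 4.6 nM.
Compound 3 `CN(C)c1nc(NCC2CCC(CNC(=O)c3ccc(Br)cc3OC(F)(F)F)CC2)nc2ccccc12` — in this assay compound 3 gives 1500 nM.

Among these three numbers compound 2 stands lowest; compound 1 is its nearest neighbour, and compound 3 lies far above both. For the measured compounds named here, the only single-point step among them is a 2.2-fold lower number from compound 1 to compound 2 (0.34 log units; beyond the scatter), the change of cyano to methyl on the aromatic carbon of the benzamide.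

Compound 4 `CN(C)c1nc(N[C@H]2CC[C@@H](NC(=O)c3ccc(Cl)c(Cl)c3)CC2)nc2ccccc12` has not yet been measured in this assay. It differs from compound 2 in one place: 3,4-dichlorophenyl in place of 3-methylphenyl on a carbonyl carbon. Going by the values given here, no measured step exchanges the whole aryl group of the amide for a dichlorinated one, so the step from compound 1 to compound 2 offers only a loose guide: a single change on that ring moved the number modestly, and compound 3, which differs in several places at once, shows only how far a combination of changes can reach. A modest shift at most is therefore expected, in no firm direction, and a 1.1-fold higher number from compound 2 to compound 4 (0.04 log units; within the scatter) is the estimated step. Compound 4 is expected to give about 5 nM, within 1.5 nM to 16 nM.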

Compound 4, half-maximal inhibitory concentration: 5 nM
The estimate for compound 4 equals the measured number at the digits printed, and the stated range covers the measured number.
By their numbers in this assay, from the lowest: compounds 2, 4 and 1 (each within the scatter of the next, the first and the last beyond it); then compound 3.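

On the aryl group at this carbonyl carbon, the exchange of 3-methylphenyl for 3,4-dichlorophenyl leaves the number in this assay unchanged within the scatter (a 1.1-fold higher number from compound 2 to compound 4 (0.04 log units; within the scatter)), so two chlorine atoms serve here as well as one methyl group. Compound 4 also lies within the scatter of the nitrile-bearing compound 1 (a 2.0-fold lower number from compound 1 to compound 4 (0.30 log units; within the scatter)), whereas compound 2 lies just beyond it (a 2.2-fold lower number from compound 1 to compound 2 (0.34 log units; beyond the scatter)). Where the earlier compounds offered a single exchange on this ring, three differently substituted phenyl groups now give closely spaced numbers on the same core.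

Still open, going by these compounds, is what a carboxylic acid or an amine on this ring would give, or a saturated cyclohexyl group in place of the phenyl ring. Nothing shown accounts for why these groups read so alike.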